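The compounds below may be only part of what the source reports. "The series", "measured", "known", "first", "only" and "open" are said of these compounds alone.

Series notes. In a functional assay on MGC-803 cells (Homo sapiens) for inhibition, read by MTT assay, with a stated time of 72 h (on this read-out higher numbers stand for weaker inhibition and lower numbers for stronger inhibition), compound 1 `O=C(/C=C/c1ccc(Cl)cc1)c1ccc(OCCSC(=S)N2CCOCC2)cc1` gives 11500 nM, the lowest of the three numbers in hand. Compound 3 `O=C(/C=C/c1cccnc1)c1ccc(OCCCSC(=S)N2CCCC2)cc1` gives 19500 nM in this assay, and its gap from compound 1 lies within the scatter. Within the data shown here, compound 2 `COc1cc(/C=C/C(=O)c2ccc(OCCSC(=S)N3CCCCC3)cc2)cc(OC)c1OC` gives 41300 nM in this assay, a gap from compound 1 that lies beyond the scatter; compound 2 also carries a different aryl on the enone, so none of the measured pairs isolates a single change.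

Compound 4 `O=C(/C=C/c1ccc(Cl)cc1)c1ccc(OCCCSC(=S)N2CCCCC2)cc1` is not yet measured. It differs from compound 1 by a group of 10 heavy atoms (7 carbon, 1 nitrogen, 2 sulfur; one six-membered non-aromatic ring with 1 hetero atom) in place of a group of 9 heavy atoms (5 carbon, 1 nitrogen, 1 oxygen, 2 sulfur; one six-membered non-aromatic ring with 2 hetero atoms), on a saturated chain carbon, two bonds along the chain from an oxygen on an aromatic ring, a six-membered non-aromatic ring with one hetero atom entering where one with two hetero atoms leaves, on a saturated chain carbon, two bonds along the chain from an oxygen on an aromatic ring. Compound 3, which shares the longer chain, sits within the scatter of compound 1, while compound 2, which shares the entering ring, gives a higher number but differs elsewhere too. The step from compound 1 to compound 4 is expected to be a 1.4-fold higher number from compound 1 to compound 4 (0.14 log units; within the scatter), modest and toward a somewhat higher number. Compound 4 is expected to give 16000 nM in this assay, in the range 6500 nM to 40000 nM.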

Compound 4, half-maximal inhibitory concentration: 56800 nM
Estimate against measurement, compound 4: 3.6-fold (0.55 log units) below, and the stated range ends below it.
By their numbers in this assay, from the lowest: compounds 1 and 3 (each within the scatter of the next); then compounds 2 and 4 (each within the scatter of the next).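

In this assay the position on a saturated chain carbon, two bonds along the chain from an oxygen on an aromatic ring, now has its first single-place reading: the step is a 4.9-fold higher number from compound 1 to compound 4 (0.69 log units; beyond the scatter) with the rest of the core of compound 1 unchanged. The group at this position therefore matters on this read-out, and the six-membered non-aromatic ring with 1 hetero atom, carried on the entering group of 10 heavy atoms, goes with the higher number. No measured property of these compounds bears on this shift.

The entering group differs from the leaving one in both its ring and its chain, so the compounds shown do not separate those two changes. Also open, from the compounds shown here alone, is whether a piperazine ring or an open dimethylamino group at this position would keep the number near that of compound 1.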